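The compounds below may be only part of what the source reports. "The series", "measured", "known", "first", "only" and "open" are said of these compounds alone.

Measured in a functional assay on A549 cells (Homo sapiens) for antiproliferative activity, read by MTT assay, with a stated time of 72 h; a higher number here means a weaker inhibitor, a lower number a stronger inhibitor:
- Compound 1 `C/C=C/C(=O)Nc1cccc(Oc2nc(Nc3ccn(C)n3)nc3c2CSCC3)c1`: > 50000 nM
- Compound 2 `C/C=C/C(=O)Nc1cccc(Oc2nc(Nc3cccc(OC)c3)nc3c2CSCC3)c1`: 21100 nM
- Compound 3 `C=CC(=O)Nc1cccc(Oc2nc(Nc3cccc(C#N)c3)nc3c2CSCC3)c1`: 6860 nM

The entry for compound 1, > 50000 nM, is a limit and not a number.

Compound 3, at 6860 nM, has the lowest of the two true numbers, and compound 2 stands at 21100 nM. Lower means stronger here, so compound 3 is the natural starting point. Compound 4 `C/C=C/C(=O)Nc1cccc(Oc2nc(Nc3cccc(C#N)c3)nc3c2CSCC3)c1` differs from compound 3 in one place, with prop-1-en-1-yl in place of vinyl on a carbonyl carbon.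

For the measured compounds named here, the only measured single-place step, an at least 2.3-fold lower number from compound 1 to compound 2 (0.37 log units; beyond the scatter), puts 3-methoxyphenyl in place of 1-methyl-1H-pyrazol-3-yl on a nitrogen on an aromatic ring. That is a different place, so it says little about this change. The nearest hint is compound 2, which carries prop-1-en-1-yl and gives 21100 nM. Compound 2 also differs from compound 3 elsewhere, so the hint is weak.

A modest move towards a higher number is therefore expected, with an estimated size of a 1.5-fold higher number from compound 3 to compound 4 (0.16 log units; within the scatter). The estimate for compound 4 is 10000 nM, with an expected range of 4000 nM to 25000 nM.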

Compound 4, half-maximal inhibitory concentration: 17200 nM
Compound 4: middle estimate off by 1.7-fold (0.24 log units), on the low side, within the range that was stated.
By their numbers in this assay, from the lowest: compound 3; then compounds 4 and 2 (each within the scatter of the next). At a limit, above all of these: compound 1.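

For the compounds shown here, putting prop-1-en-1-yl in place of vinyl on a carbonyl carbon, with nothing else altered, gives a 2.5-fold higher number from compound 3 to compound 4 (0.40 log units; beyond the scatter) in this assay and is the first reading of this position on its own. By contrast, cyano in place of methoxy on an aromatic carbon, with prop-1-en-1-yl kept on the carbonyl carbon, gives a 1.2-fold lower number from compound 2 to compound 4 (0.09 log units; within the scatter) and so stays within the scatter, which means that the earlier gap between compound 2 and compound 3 tracks the carbonyl side of the molecule in this pair of steps. Compound 1 carries a limit and not a number, so the step with 3-cyanophenyl in place of 1-methyl-1H-pyrazol-3-yl on the nitrogen, an at least 2.9-fold lower number from compound 1 to compound 4 (0.46 log units; beyond the scatter) in size, is a bound only: the limit of > 50000 nM in this assay, at which 1 of the 4 values shown sits.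

Going by these compounds, only vinyl and prop-1-en-1-yl appear on this carbonyl carbon, so it remains open how a saturated ethyl group, a longer chain or a chain ending in a dimethylamino group would read. Vinyl also appears with only one group on the nitrogen, so it remains open whether the same step would hold with 3-methoxyphenyl there.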